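Compound 2 to compound 4: hydroxy to fluoro

The source may hold more compounds than are shown below. What is called first, only, known or untested is meant among the compounds shown, and "the series" means these compounds.

Measured so far in a functional assay on HeLa cells (Homo sapiens) for antiproliferative activity, read by sulforhodamine B assay, with a stated time of 48 h (on this read-out lower numbers stand for stronger inhibition and higher numbers for weaker inhibition), for three compounds
compound 1 `COc1cc(OC)c2sc(-c3ccc(N/C=C\C(=O)c4ccc(OC)c(O)c4)c(C)c3)nc2c1` gives 16100 nM
compound 2 `COc1ccc(C(=O)/C=C\Nc2ccc(-c3nc4cc(OC)c(OC)c(OC)c4s3)cc2C)cc1O` gives 11400 nM
compound 3 `COc1ccc2nc(-c3ccc(N/C=C\C(=O)c4ccc(OC)c(O)c4)c(C)c3)sc2c1` gives 12000 nM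

Compound 2 at 11400 nM is not separated from the other two compounds, since its gaps to compound 1 and compound 3 both lie within the scatter. The step followed here leads to the unmeasured compound 4 `COc1ccc(C(=O)/C=C\Nc2ccc(-c3nc4cc(OC)c(OC)c(OC)c4s3)cc2C)cc1F` through fluoro in place of hydroxy on an aromatic carbon in the aryl group, turning 3-hydroxy-4-methoxyphenyl into 3-fluoro-4-methoxyphenyl. This is fluoro in place of hydroxy on an aromatic carbon, ortho to a methoxy group.

Among the measured compounds shown here, the only measured step between compounds differing in one place is a 1.4-fold lower number from compound 1 to compound 2 (0.15 log units; within the scatter) for methoxy in place of hydrogen on an aromatic carbon, and it stays within the scatter. That step does not touch the hydroxy group. Compound 1, compound 2 and compound 3 all carry the 3-hydroxy-4-methoxyphenyl group, so no measurement here shows what replacing the hydroxy does. No direction can be argued from these data, and no change beyond the scatter is expected, with a wide margin for an untested kind of replacement. The estimated move is a 1.1-fold higher number from compound 2 to compound 4 (0.02 log units; within the scatter) and no direction is claimed for it. In this assay the expected value for compound 4 is 12000 nM with an estimated range from 4000 nM to 35000 nM for repeat measurements.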

Compound 4, half-maximal inhibitory concentration: 1200 nM
For compound 4 the middle estimate is 10-fold (1.00 log units) above the measured one, and the stated range ends above it.
By their numbers in this assay, from the lowest: compound 4; then compounds 2, 3 and 1 (each within the scatter of the next).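

In this assay, fluoro in place of hydroxy on the aromatic carbon ortho to a methoxy group gives a 9.5-fold lower number from compound 2 to compound 4 (0.98 log units; beyond the scatter) and, unlike the earlier step on the core, this one lies beyond the scatter. This position on the aryl group therefore responds to substitution, whereas compounds 1, 2 and 3 all carried the same 3-hydroxy-4-methoxyphenyl group and could not show this. The hydroxy group is also not needed for antiproliferative activity in this compound pair, since 3-fluoro-4-methoxyphenyl gives the lower number, and nothing available bears on why this replacement has this effect.

The compounds shown leave open whether the gain belongs to fluoro itself or simply follows the loss of hydroxy, which plain hydrogen, chloro, an amine or a methyl group at this position would help to separate. They also leave open whether the same replacement gives a comparable step on the cores of compound 1 and compound 3, where the hydroxy group remains in place.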